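Amide-nitrogen substituent change in a cytotoxicity series

This account rests on a few compounds, and the source may have more. Where it says the series, first, only, none or still open, it means among the compounds named here.

Compound 2 `O=C(CCSc1nnc(-c2ccncc2)s1)Nc1ccccc1` stands only at a limit rather than a number: in an ADME assay on BHK-21 cells (Mesocricetus auratus) for cytotoxicity, with a stated time of 3 days (on this read-out lower numbers stand for higher toxicity in this test and higher numbers for lower toxicity in this test), compound 2 gives > 50000 nM. Compound 1 `CC(Sc1nnc(-c2ccncc2)s1)C(=O)NCc1ccccc1` likewise reaches only the limit, giving > 50000 nM in this assay. Compound 3 `CC(CSc1nnc(-c2ccncc2)s1)C(=O)Nc1ccccc1` gives > 50000 nM in this assay, again a limit. All three values sit at the limit of > 50000 nM in this assay, at which 3 of the 3 values shown sit. Going by the values given here, the single step between measured neighbours, a step that the two limits leave unreadable from compound 2 to compound 3, is therefore not readable in size. Compound 4 `O=C(CCSc1nnc(-c2ccncc2)s1)NCc1ccc(Cl)cc1` differs from compound 2 by 4-chlorobenzyl in place of phenyl on an amide-type nitrogen. Among the compounds with values here, no measured step bears on that change, and the only step known gives no size. The expectation for compound 4 is therefore that it also stays at the limit, an estimated 60000 nM with a range of 30000 nM to 200000 nM, corresponding to an expected step that the limit leaves unreadable from compound 2 to compound 4.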

Compound 4, half-maximal cytotoxic concentration: 21500 nM
Compound 4: middle estimate off by 2.8-fold (0.45 log units), on the high side, outside the stated range (below it).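

In this assay, going by these compounds alone, 4-chlorobenzyl in place of phenyl on an amide-type nitrogen gives an at least 2.3-fold lower number from compound 2 to compound 4 (0.36 log units; beyond the scatter), the first step whose size can be read, and it points towards higher toxicity in this test. Compound 2 stands only at a limit, so this size is a minimum. The other steps cannot be read, and compound 4 alone leaves the limit: the limit of > 50000 nM in this assay, at which 3 of the 4 values shown sit.

Open, going by these compounds, is whether plain benzyl on this nitrogen gives the same step or whether the chlorine is needed. On these data alone, an amine or a carboxylic acid in place of the chlorine also remains open.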